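The source may report more compounds than this note shows. Statements on the series, on what has been measured and on what is new or still open speak of the compounds shown alone.

Measured so far in a functional assay, read by spectrophotometry, with a stated time of 30 min (on this read-out lower numbers stand for stronger inhibition and higher numbers for weaker inhibition), are these compounds:
Compound 1 `CC(C)(C)c1cc(CCC(=O)NC2CCN(Cc3ccccc3)CC2)cc(C(C)(C)C)c1O` gives 80300 nM
Compound 2 `CC(C)(C)c1cc(/C=C/C(=O)NCC2CCN(Cc3ccccc3)CC2)cc(C(C)(C)C)c1O` gives 75600 nM
Compound 3 `Cc1ccccc1CN1CCC(CCNC(=O)/C=C/c2cc(C(C)(C)C)c(O)c(C(C)(C)C)c2)CC1` gives 65300 nM

Compound 3 stands level with the other two compounds. Its 65300 nM lies within the scatter of both compound 2 at 75600 nM and compound 1 at 80300 nM and the read-out does not separate the three. Within the data shown here, these compounds differ from one another in more than one place, and no measured pair isolates a single change.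

The next compound to be tested, compound 4 `CC(C)(C)c1cc(/C=C/C(=O)NCCC2CCN(Cc3ccccc3Cl)CC2)cc(C(C)(C)C)c1O`, differs from compound 3 in one place. The change is chloro in place of methyl on an aromatic carbon with chloro in place of methyl on an aromatic carbon, ortho to a large group, so that 2-methylbenzyl becomes 2-chlorobenzyl.

No step beyond the scatter is expected in this assay for this change. That expectation rests on compound 3 at 65300 nM and compound 2 at 75600 nM which stay within the scatter of each other despite differing in more than one place. The data hold no direct measure of this particular swap. The estimated 1.1-fold lower number from compound 3 to compound 4 (0.04 log units; within the scatter) is therefore expected to stay within the scatter. For compound 4 the estimated value is 60000 nM with an expected range from 30000 nM to 120000 nM in this measurement.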

Compound 4, half-maximal inhibitory concentration: 80200 nM
For compound 4 the middle estimate is 1.3-fold (0.13 log units) below the measured one; the range from low to high includes it.
By their numbers in this assay, from the lowest: compounds 3, 2, 4 and 1 (each within the scatter of the next).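

In this assay, replacing 2-methylbenzyl with 2-chlorobenzyl gives a 1.2-fold higher number from compound 3 to compound 4 (0.09 log units; within the scatter), and this is the only pair shown that differs in one place, so it is the first direct reading of a single change in this set. On this aromatic carbon, ortho to a large group, methyl and chloro are not separated by the read-out, and neither group can be ranked above the other; the swap of one heavy atom for another, with no hydrogen-bond donors or acceptors on either side, leaves the compounds level. No independent measurement bears on why the two groups read alike, so the result stands as an observation without an explanation.

The compounds shown leave open whether any group at this position can move the number beyond the scatter, for instance a methoxy, a nitrile or an amine on the same aromatic carbon. They also leave open whether the same swap would read alike with a different chain between the amide and the piperidine-bearing part of the core, or at another carbon of the same aromatic ring.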